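The source may report more compounds than this note shows. Statements on the series, on what has been measured and on what is new or still open speak of the compounds shown alone.

Measured so far in a functional assay on PC-3 cells (Homo sapiens) for cytotoxicity, read by MTT assay, with a stated time of 48 h; on this read-out higher numbers stand for weaker inhibition and lower numbers for stronger inhibition:
- compound 1 `CCC(=O)N1N=C(c2cc3ccccc3oc2=O)CC1c1ccccc1`; compound 1 gives 4370 nM
- compound 2 `O=C(CNC1CC1)N1N=C(c2cc3ccccc3oc2=O)CC1c1ccccc1`; compound 2 gives 28500 nM
- compound 3 `CCN(CC)C1CCN(CC(=O)N2N=C(c3cc4ccccc4oc3=O)CC2c2ccccc2)CC1`; compound 3 gives 26100 nM

Compound 3 stands second highest of the three numbers. Its nearest neighbour is compound 2, with a 1.1-fold lower number from compound 2 to compound 3 (0.04 log units; within the scatter) lying within the scatter, so the two cannot be ordered. Compound 1 is the outlier on the low side: a 6.0-fold higher number from compound 1 to compound 3 (0.78 log units; beyond the scatter).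

Compound 4 `NC(=O)C1CCN(CC(=O)N2N=C(c3cc4ccccc4oc3=O)CC2c2ccccc2)CC1` differs from compound 3 in one place: carbamoyl in place of diethylamino on a saturated ring carbon. Among the compounds with values here, no measured step touches this position; the steps recorded all concern the chain carbon bound to the carbonyl. There, a 6.5-fold higher number from compound 1 to compound 2 (0.81 log units; beyond the scatter) and a 6.0-fold higher number from compound 1 to compound 3 (0.78 log units; beyond the scatter) were of about the same size, and a 1.1-fold lower number from compound 2 to compound 3 (0.04 log units; within the scatter) showed two quite different groups at that carbon giving the same number. On that basis the exchange of substituents on the six-membered ring of compound 3 is expected to leave the number about where it is, and the step of a 1.0-fold lower number from compound 3 to compound 4 (0.02 log units; within the scatter) is estimated as none beyond the scatter. Compound 4 is therefore estimated at 25000 nM, with a range from 9000 nM to 60000 nM.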

Compound 4, half-maximal inhibitory concentration: 8310 nM
Compound 4: the middle estimate sits 3.0-fold (0.48 log units) above what was measured; measured number outside the range, below it.
By their numbers in this assay, from the lowest: compounds 1 and 4 (each within the scatter of the next); then compounds 3 and 2 (each within the scatter of the next).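

In this assay, the saturated ring carbon of the six-membered ring is not a silent position: carbamoyl in place of diethylamino gives a step beyond the scatter (a 3.1-fold lower number from compound 3 to compound 4 (0.50 log units; beyond the scatter)). The chain carbon bound to the carbonyl therefore no longer reads as a plateau once methyl is replaced, since 4-carbamoylpiperidin-1-yl in place of cyclopropylamino also gives a step beyond the scatter (a 3.4-fold lower number from compound 2 to compound 4 (0.54 log units; beyond the scatter)), while in place of methyl it stays within the scatter (a 1.9-fold higher number from compound 1 to compound 4 (0.28 log units; within the scatter)). No measurement shown here accounts for these steps.

A primary amine or a carboxylic acid on the same ring carbon would test whether the step follows carbamoyl itself or the departure of diethylamino. Going by these compounds, whether a longer chain between the carbonyl and the piperidine nitrogen preserves the step remains open.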